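This account rests on a few compounds, and the source may have more. Where it says the series, first, only, none or still open, it means among the compounds named here.

Of the compounds shown here, two have been measured in an ADME assay on microsomes from liver (Homo sapiens) for metabolic stability, read by LC-MS, using NADPH, with a stated time of 60 min, tested at 1 uM; on this read-out lower numbers stand for slow clearance and higher numbers for fast clearance. Compound 1, `COc1ccc(C(F)(F)F)cc1CN(C1CC1)C(c1cccnc1)c1nnnn1-c1ccccc1C`, gives 154 uL/min in this assay. Among the measured compounds shown here, compound 2, `Cc1ccccc1-n1nnnc1C(c1cccnc1)N(Cc1cccc(C(F)(F)F)c1)C1CC1`, gives 360 uL/min in this assay, the highest of the two numbers available; the only measured step is a 2.3-fold higher number from compound 1 to compound 2 (0.37 log units; beyond the scatter), which puts compound 2 beyond the scatter above compound 1.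

The next compound, compound 3, is `Cc1ccccc1-n1nnnc1C(c1cncnc1)N(Cc1cccc(C(F)(F)F)c1)C1CC1`. It differs from compound 2 in one place: pyrimidin-5-yl in place of pyridin-3-yl on a saturated chain carbon bound to an amine nitrogen and an aromatic carbon. For the measured compounds named here, no measured step touches the group on the saturated chain carbon bound to the amine nitrogen and the aromatic carbon; the single step that exists concerns a group on an aromatic carbon elsewhere in the core and therefore gives no direct guide. Without a bearing step, compound 3 is expected to sit near compound 2, and the estimated step of a 1.2-fold lower number from compound 2 to compound 3 (0.08 log units; within the scatter) is expected to stay within the scatter. The estimate for compound 3 in this assay is 300 uL/min, with a range from 150 uL/min to 600 uL/min.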

Compound 3, intrinsic clearance in a liver preparation (reported as CLH), per the amount of preparation that the assay uses in the Homo sapiens assay: 261 uL/min
Estimate against measurement, compound 3: 1.1-fold (0.06 log units) above; the range from low to high includes it.
By their numbers in the Homo sapiens assay, from the lowest: compounds 1, 3 and 2 (each within the scatter of the next, the first and the last beyond it).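

Among the compounds shown here, the exchange of pyridin-3-yl for pyrimidin-5-yl on a saturated chain carbon bound to an amine nitrogen and an aromatic carbon gives the first reading at this position: in the Homo sapiens assay the step is a 1.4-fold lower number from compound 2 to compound 3 (0.14 log units; within the scatter) and so cannot be told apart from repeat measurement. In a physicochemical assay for solubility, read by HPLC, in phosphate buffer, measured as kinetic solubility, at pH 6.5 (a higher number here means a more soluble compound, a lower number a less soluble compound), compound 2 gives 1.5 ug/mL and compound 3 gives 1.5 ug/mL, and the step reads no change at the digits printed from compound 2 to compound 3 (within the scatter), so neither read-out separates a six-membered aromatic ring with 1 hetero atom from one with 2 hetero atoms at this position. Nothing available bears on why the two compounds read alike in both assays.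

As far as these compounds go, both groups seen at this position are six-membered aromatic rings containing nitrogen, so it remains open how a phenyl ring, a piperidine or a carboxylic acid on that carbon would read in either assay. For the compounds shown here, also open is whether methoxy on the aromatic carbon of the core, the one other change, would give a comparable step when pyrimidin-5-yl stands on the saturated chain carbon.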